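The compounds below may be only part of what the source reports. "The series", "measured", "known", "first", "only" and "open" are said of these compounds alone.

For the measured compounds named here, compound 2 `CNC[C@@H]1CCN(c2c(F)cc3c(=O)c(C(=O)O)cn(Cc4ccc(-c5ccccc5)cc4)c3c2OC)C1` is the only compound with a plain number in an assay on isolated protein for inhibition of DNA topoisomerase 1 (Homo sapiens), with a stated time of 15 min; on this read-out higher numbers stand for weaker inhibition and lower numbers for stronger inhibition: compound 2 gives 155000 nM. Compound 1 `CNCCNc1c(F)cc2c(=O)c(C(=O)O)cn(Cc3ccc(-c4ccccc4)cc3)c2c1OC` reaches only a limit in this assay, reported as > 200000 nM. Going by the values given here, the sole measured step, an at least 1.2-fold lower number from compound 1 to compound 2 (0.11 log units; that floor lies within the scatter), bears directly on the change to compound 3 `COc1c(NCCN)c(F)cc2c(=O)c(C(=O)O)cn(Cc3ccc(-c4ccccc4)cc3)c12`, which is (2-aminoethyl)amino in place of 3-((methylamino)methyl)pyrrolidin-1-yl on an aromatic carbon. This change reverses the measured step. Compound 3 is expected to move back toward the limit, an estimated step of a 1.3-fold higher number from compound 2 to compound 3 (0.11 log units; within the scatter). Compound 3 is estimated at 200000 nM, in a range from 100000 nM to 400000 nM.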

Compound 3, half-maximal inhibitory concentration: > 200000 nM
Compound 3 gave a limit, no number; the forecaster's own chance of this, stated with the estimate: 55%; the middle value lies on the limit itself.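

In this assay compound 3 gives > 200000 nM, which is a limit and not a number. Exchanging the pyrrolidine for the open (2-aminoethyl)amino chain on this aromatic carbon gives an at least 1.2-fold higher number from compound 2 to compound 3 (0.11 log units; that floor lies within the scatter), so the change is not shown to exceed the scatter. The step between compound 1 and compound 3, hydrogen in place of methyl on an amine nitrogen, cannot be read because both compounds stand at the same limit: the limit of > 200000 nM in this assay, at which 2 of the 3 values shown sit.

As far as these compounds go, whether a piperazin-1-yl group or a longer chain such as (3-aminopropyl)amino on this carbon would give a clearly lower number stays open.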